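Swapping an Acid for an Amine on a Cyclohexyl Linker

This account rests on a few compounds, and the source may have more. Where it says the series, first, only, none or still open, it means among the compounds named here.

Measured compounds:
- compound 1 `Cc1cc2c(cc1Cc1ccc(C(=O)NC[C@H]3CC[C@H](C(=O)O)CC3)o1)C(C)(C)CCC2(C)C`: 3000 nM
- compound 2 `Cc1cc2c(cc1Cc1ccc(C(=O)NCC3CCC(CNC(=O)C(F)(F)F)CC3)o1)C(C)(C)CCC2(C)C`: 2720 nM
- compound 3 `Cc1cc2c(cc1Cc1ccc(C(=O)NCC3CCC(CNCc4cc(O)nc(O)n4)CC3)o1)C(C)(C)CCC2(C)C`: 865 nM

In an assay on isolated protein for binding affinity to Gonadotropin-releasing hormone receptor (Rattus norvegicus) (a lower number here means a stronger inhibitor, a higher number a weaker inhibitor), compound 1 gives 3000 nM, the highest of the three numbers. Compound 2 sits within the scatter of it, so the two cannot be told apart. Compound 3 is the only one clearly separated: the step of a 3.1-fold lower number from compound 2 to compound 3 (0.50 log units; beyond the scatter) shows a modest gain.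

Compound 4 `Cc1cc2c(cc1Cc1ccc(C(=O)NCC3CCCC(CN)C3)o1)C(C)(C)CCC2(C)C` has not been measured. It differs from compound 1 by 3-(aminomethyl)cyclohexyl in place of 4-carboxycyclohexyl on a saturated chain carbon bound to an amide-type nitrogen, so the acid end of the linker becomes a basic amine. Among the measured compounds shown here, no measured step covers this exact change. For the measured compounds named here, the nearest hint is that compound 3, the one measured compound carrying an amine nitrogen in this region, gives 865 nM, while the acid in compound 1 and the trifluoromethyl carbonyl in compound 2 both give weaker numbers. On that thin basis a modest improvement is expected, with wide uncertainty, as a 2.0-fold lower number from compound 1 to compound 4 (0.30 log units; within the scatter). The estimate for compound 4 in this assay is 1500 nM, within a range of 400 nM to 5000 nM.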

Compound 4, inhibition constant: 890 nM
The estimate for compound 4 lay 1.7-fold (0.23 log units) above the measured number, and the stated range covers the measured number.
By their numbers in this assay, from the lowest: compounds 3 and 4 (each within the scatter of the next); then compounds 2 and 1 (each within the scatter of the next).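

In this assay, among the compounds shown here, the change to 3-(aminomethyl)cyclohexyl gives a 3.4-fold lower number from compound 1 to compound 4 (0.53 log units; beyond the scatter), the first measured step that starts from the carboxylic acid end of the linker. It shows that this position, on a saturated chain carbon bound to an amide-type nitrogen, responds to the group placed there, and that the number improves with the carboxylic acid gone. No measurement shown gives a reason for this gain.

Going by these compounds, this single step changes two things at once, the acid becoming an aminomethyl group and the number on the ring going from 4 to 3, so their separate contributions stay unknown. The compounds shown leave open how 4-(aminomethyl)cyclohexyl or 3-carboxycyclohexyl would compare, and either one would separate the choice of group from its place on the ring.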